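Swapping the aryl group on a fused core

The compounds below may be only part of what the source reports. "The series", "measured", "known", "first", "only" and "open" are said of these compounds alone.

Compound 3 `COc1ccc(F)cc1CNCCCNc1ccnc2cc(-c3ccc(C(C)(C)C)cc3)ccc12` gives the highest of the three numbers in a physicochemical assay for solubility, with a stated time of 18 h, at pH 7.4 (a lower number here means a less soluble compound, a higher number a more soluble compound), at 32000 nM. Compound 2 `COc1cccc(CNCCCNc2ccnc3cc(Oc4cccc(N(C)C)c4)ccc23)c1O` gives 14500 nM, and compound 1 `COc1ccc(F)cc1CNCCCNc1ccnc2cc(Cc3ccc(C#N)cc3)ccc12` gives 4200 nM. Within the data shown here, the only single-point step known is a 7.6-fold higher number from compound 1 to compound 3 (0.88 log units; beyond the scatter). Compound 4 `COc1ccc(F)cc1CNCCCNc1ccnc2cc(Oc3cccc(N(C)C)c3)ccc12` differs from compound 3 by 3-(dimethylamino)phenoxy in place of 4-(tert-butyl)phenyl on an aromatic carbon. Among the measured compounds shown here, no measured step covers this exact change; compound 2 carries the same entering group on a different benzyl portion, and its value sits lower than that of compound 3, so a modest fall in this assay seems plausible. Compound 4 is therefore expected to give 18000 nM, with a likely range of 7000 nM to 45000 nM. The estimated step of a 1.8-fold lower number from compound 3 to compound 4 (0.25 log units; within the scatter) is expected to be moderate rather than large.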

Compound 4, solubility: 14500 nM
Compound 4: the middle estimate sits 1.2-fold (0.09 log units) above what was measured; measured number inside the range.
By their numbers in this assay, from the lowest: compound 1; then compounds 2 and 4 (each within the scatter of the next); then compound 3.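

In this assay 3-(dimethylamino)phenoxy on this aromatic carbon now has a measured step against each of the other two groups: in place of 4-(tert-butyl)phenyl (a 2.2-fold lower number from compound 3 to compound 4 (0.34 log units; beyond the scatter)) and in place of 4-cyanobenzyl (a 3.5-fold higher number from compound 1 to compound 4 (0.54 log units; beyond the scatter)). It therefore reads lower than the first group and higher than the second, both beyond the scatter. With that group held, 5-fluoro-2-methoxyphenyl in place of 2-hydroxy-3-methoxyphenyl leaves the number unmoved (no change at the digits printed from compound 2 to compound 4 (within the scatter)). From the compounds shown here alone, whether a morpholine or a carboxylic acid on the same carbon would shift the number remains open. Nothing offered here accounts for these steps.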